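This account rests on a few compounds, and the source may have more. Where it says the series, first, only, none or still open, it means among the compounds named here.

For the measured compounds named here, in a functional assay on HCT-116 cells (Homo sapiens) for inhibition, read by MTT assay, with a stated time of 48 h (a lower number here means a stronger inhibitor, a higher number a weaker inhibitor), compound 1 (`O=C(CCCCOc1no[n+]([O-])c1S(=O)(=O)c1ccccc1)NO`) gives 2180 nM and compound 2 (`CC(C)(COc1no[n+]([O-])c1S(=O)(=O)c1ccccc1)C(=O)NO`) gives 9740 nM, the higher of the two numbers so far. Compound 3 (`CCCC(C)(COc1no[n+]([O-])c1S(=O)(=O)c1ccccc1)C(=O)NO`) departs from compound 2 by ethyl in place of hydrogen on a saturated chain carbon, two bonds along the chain from a carbonyl carbon. Going by the values given here, only one measured step touches this chain, a 4.5-fold higher number from compound 1 to compound 2 (0.65 log units; beyond the scatter), and it is modest. Among the compounds with values here, no measured step adds ethyl at this carbon, so the guide is weak and the range stays wide. No change beyond the scatter is expected in this assay, and the expected step is a 1.4-fold lower number from compound 2 to compound 3 (0.14 log units; within the scatter). For compound 3 the estimated value is 7000 nM, within an expected range of 2800 nM to 18000 nM.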

Compound 3, half-maximal inhibitory concentration: 66100 nM
Estimate against measurement, compound 3: 9.4-fold (0.98 log units) below, and the stated range ends below it.
By their numbers in this assay, from the lowest: compound 1; then compound 2; then compound 3.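

In this assay, the change at this saturated chain carbon, read also as methyl to propyl, gives a 6.8-fold higher number from compound 2 to compound 3 (0.83 log units; beyond the scatter), so a substituent change at this one carbon alone moves the number beyond the scatter. The earlier step changed the chain as a whole and could not isolate this carbon. Nothing available explains the rise.

The compounds shown leave open whether a chain longer than propyl at this carbon raises the number further. Also open, from the compounds shown here alone, is how an amine or a carboxylic acid at this carbon would read.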